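Swapping a dimethylamino for an acetyl on compound 1

A few compounds are considered here, and "the series" means these few. Any claim that something is new, unique, unknown or untested is made for them only; others in the source may bear on it.

Measured so far:
- compound 1, `COc1cc(C)cc(-c2c(-c3ccnc(-c4ccc(N(C)C)cc4)c3)cnn2CC#N)c1`, 14%
- compound 2, `Cc1cc(O)cc(-c2nn(CC#N)cc2-c2ccnc(-c3ccc(Oc4ccccc4)cc3)c2)c1`, 101%

Both compounds were tested in a functional assay on SK-MEL-2 cells (Homo sapiens) for cytotoxicity, read by sulforhodamine B assay, with a stated time of 48 h, tested at 100 nM; a lower number here means a stronger effect, a higher number a weaker effect of the compound at the concentration tested. Compound 1 gives 14%, the lowest of the two numbers, and compound 2 gives 101%, a number far above it and well beyond the scatter of repeated measurements. The two compounds differ in several places at once, so their pair shows only that one strong and one very weak result sit among them, not which change is responsible.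

Compound 3, `COc1cc(C)cc(-c2c(-c3ccnc(-c4ccc(C(C)=O)cc4)c3)cnn2CC#N)c1`, has not been measured. It differs from compound 1 in one place: acetyl in place of dimethylamino on an aromatic carbon. Going by the values given here, no measured pair with this single change exists here, so the size and direction of its effect are unknown; the only guidance is how far compound 1 sits from compound 2. The expected step of a number 31 percentage points higher from compound 1 to compound 3 (beyond the scatter) is a weakening, with a wide margin. For compound 3 the estimate is 45%, expected between 10% and 95%.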

Compound 3, a percentage reported as activity, at one concentration (the size of the read-out at that concentration, not a potency): 103%
Compound 3: the middle estimate sits 58 percentage points below what was measured; the measured number lies above the stated range.
By their numbers in this assay, from the lowest: compound 1; then compounds 2 and 3 (each within the scatter of the next).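

The exchange of dimethylamino for acetyl gives a number 89 percentage points higher from compound 1 to compound 3 (beyond the scatter) in this assay and so, unlike the earlier pair of compounds that differed in several places, ties a large weakening of the effect to one place alone. The rest of the molecule stays the same, which shows that the shared core does not secure the effect at the concentration tested and that the group at this position matters greatly. The two groups match in heavy-atom count, hydrogen-bond donors, hydrogen-bond acceptors and net charge, so these counts do not separate them, and no measurement shown explains why the exchange has so large an effect.

The compounds shown leave open whether dimethylamino itself is needed here or whether another group could serve equally well, such as a primary amine, a morpholine ring or a carboxylic acid. They also leave open whether the same exchange would have an effect of similar size if the core were changed elsewhere, since it is seen only once, on the core of compound 1.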